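Fluoro to chloro step on two different cores

This account rests on a few compounds, and the source may have more. Where it says the series, first, only, none or still open, it means among the compounds named here.

Compound 1 `Cc1cc(C)cc(NC(=O)COc2cc(C)nc3ccc(F)cc23)c1` and compound 2 `Cc1cc(C)cc(NC(=O)COc2cc(C)nc3ccc(Cl)cc23)c1` share one core. In a physicochemical assay for lipophilicity, read by HPLC, in phosphate buffer, measured as chromatographic lipophilicity, at pH 7.4 (a higher number here means a more lipophilic compound, a lower number a more polar compound), compound 1 gives 5.79 and compound 2 gives 6.38; the change chloro in place of fluoro on an aromatic carbon makes a step of a number 0.59 log units higher from compound 1 to compound 2 (beyond the scatter). Compound 3 `COc1ccc2nc(C)cc(OCC(=O)Nc3ccc(F)cc3)c2c1` sits on a second core and in this assay gives 4.49. The difference between the two cores is not broken down here. Compound 4 `COc1ccc2nc(C)cc(OCC(=O)Nc3ccc(Cl)cc3)c2c1` is not yet measured; it differs from compound 3 by chloro in place of fluoro on an aromatic carbon. This is the same kind of change as in the first pair, though the place differs: here the ring is of carbon only and the site is para to a large group, whereas in compound 2 the ring is part of a fused or bridged system of two rings, meta and para to a fused ring. A step of a number 0.56 log units higher from compound 3 to compound 4 (beyond the scatter) is expected because a number 0.59 log units higher from compound 1 to compound 2 (beyond the scatter) was seen for the same change. Compound 4 is estimated at 5.05, within 4.75 to 5.35.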

Compound 4, distribution coefficient: 5.15
Compound 4: middle estimate off by 0.10 log units, on the low side; the measured number falls inside the stated range.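

In this assay, replacing fluoro with chloro gives a number 0.66 log units higher from compound 3 to compound 4 (beyond the scatter), in the same direction as a number 0.59 log units higher from compound 1 to compound 2 (beyond the scatter), so in these two pairs the change carries from one core to the other, each step beyond the scatter. This rests on two pairs with the halogen at different places, and it does not show that the step would hold on any further core or at any other place. Nothing given here bears on why the two steps run alike.

Going by these compounds, it remains open how an amine or a carboxylic acid in place of the chloro of the 4-chlorophenyl group would read in this assay. The contribution of each difference between the two cores also stays unresolved: compound 1 and compound 3 differ in more than one place.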